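Methyl in place of acetyl on the sulfur

The source may report more compounds than this note shows. Statements on the series, on what has been measured and on what is new or still open speak of the compounds shown alone.

In a functional assay on MDA-MB-231 cells (Homo sapiens) for inhibition, read by MTT assay, with a stated time of 96 h (a lower number here means a stronger inhibitor of growth, a higher number a weaker inhibitor of growth), compound 1 (`CC(C)C(=O)SCCCCCCNC(=O)c1cc(-c2ccncc2)n[nH]1`) gives > 50000 nM, which is a limit of the assay. Compound 2 (`CC(=O)SCCCCCCNC(=O)c1cc(-c2ccncc2)n[nH]1`) gives > 50000 nM, also a limit, and the limit of > 50000 nM in this assay, at which 2 of the 2 values shown sit, covers both compounds. Going by the values given here, the only measured step is a step that the two limits leave unreadable from compound 1 to compound 2, so its size offers no guide, and it concerns a carbonyl carbon rather than the sulfur. Compound 3 (`CSCCCCCCNC(=O)c1cc(-c2ccncc2)n[nH]1`) has methyl in place of acetyl on a sulfur. In this assay no step beyond the scatter is expected, in either direction. The expected step is a number no higher from compound 2 to compound 3 (the limit leaves the size open). For compound 3 the estimated value is 50000 nM, with an expected range of 20000 nM to 100000 nM.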

Compound 3, concentration for 50% growth inhibition: > 50000 nM
Compound 3: a limit, no number; the forecaster's own chance of this, stated with the estimate: 85%; the middle value sits exactly at the limit.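

Going by these compounds alone, compound 3 also sits at a limit of the assay, so no step among compound 1, compound 2 and compound 3 can be read: the limit of > 50000 nM in this assay, at which 3 of the 3 values shown sit. From the compounds shown here alone, whether the group on the sulfur changes growth inhibition in this assay stays open.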